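Tetrazole to thiadiazole on the sulfur of compound 3

This account rests on a few compounds, and the source may have more. Where it says the series, first, only, none or still open, it means among the compounds named here.

compound 1, `Cc1ccc2oc(SCC(=O)Nc3ccc(-c4nc(-c5ccccc5)c(-c5ccccc5)n4C)cc3)nc2c1`: 11%
compound 2, `Cn1c(-c2ccc(NC(=O)CSc3nc4ccccc4s3)cc2)nc(-c2ccccc2)c1-c1ccccc1`: 9.8%
compound 3, `Cn1nnnc1SCC(=O)Nc1ccc(-c2nc(-c3ccccc3)c(-c3ccccc3)n2C)cc1`: 38%

In a functional assay on HT-29 cells (Homo sapiens) for cytotoxicity, read by MTT assay, with a stated time of 24 h, tested at 0.64 ug/mL (on this read-out lower numbers stand for a weaker effect and higher numbers for a stronger effect at the one concentration tested), compound 3 gives 38%, the highest of the three numbers, while compound 1 gives 11% and compound 2 gives 9.8%. Compound 4 is `Cc1nnc(SCC(=O)Nc2ccc(-c3nc(-c4ccccc4)c(-c4ccccc4)n3C)cc2)s1`. It differs from compound 3 in one place: 5-methyl-1,3,4-thiadiazol-2-yl in place of 1-methyl-1H-tetrazol-5-yl on a sulfur.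

For the measured compounds named here, three measured steps concern the group on that sulfur. The step of a number 1.2 percentage points lower from compound 1 to compound 2 (within the scatter) exchanges one two-ring group for another and stays within the scatter. The steps of a number 27 percentage points higher from compound 1 to compound 3 (beyond the scatter) and a number 28.2 percentage points higher from compound 2 to compound 3 (beyond the scatter) each replace such a group with the 1-methyl-1H-tetrazol-5-yl group and rise beyond the scatter. Going by the values given here, no measured step exchanges one five-membered ring for another, so the change to compound 4 has no direct precedent. Because the two rises a number 27 percentage points higher from compound 1 to compound 3 (beyond the scatter) and a number 28.2 percentage points higher from compound 2 to compound 3 (beyond the scatter) both arrive at the compound with the small ring, compound 4, which keeps a five-membered ring on the sulfur, is expected to stay nearer compound 3 than compounds 1 and 2, with a modest downward step a number 10 percentage points lower from compound 3 to compound 4 (within the scatter) held possible. Compound 4 is therefore estimated at 28%, within 10% to 45%.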

Compound 4, a percentage reported as activity, at one concentration (the size of the read-out at that concentration, not a potency): 34.8%
Estimate against measurement, compound 4: 6.8 percentage points below; low and high end bracket the measured number.
By their numbers in this assay, from the lowest: compounds 2 and 1 (each within the scatter of the next); then compounds 4 and 3 (each within the scatter of the next).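

In this assay, for the compounds shown here, the step of a number 3.2 percentage points lower from compound 3 to compound 4 (within the scatter) is the only measured exchange of one five-membered aromatic ring for another on this sulfur, and it shows that the number at this position does not depend on the 1-methyl-1H-tetrazol-5-yl group alone, since 5-methyl-1,3,4-thiadiazol-2-yl, with a different set of hetero atoms, serves as well. The thiadiazole also stands clear of both two-ring groups, with a number 25 percentage points higher from compound 2 to compound 4 (beyond the scatter) and a number 23.8 percentage points higher from compound 1 to compound 4 (beyond the scatter), so among these four compounds the two carrying a single five-membered ring lie above the two carrying two-ring groups, and no compound shown goes against this. No measurement at hand offers a reason for these steps.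

The compounds shown leave open whether the pattern depends on an aromatic ring at all, as an open chain such as a butyl group on the sulfur, or a six-membered ring such as pyridine, would test. They also leave open what the methyl on either five-membered ring contributes, and whether a carboxylic acid or an amine on that ring would keep the number in this assay where it stands.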